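The compounds below may be only part of what the source reports. "The series", "measured", "known", "first", "only" and "open" are said of these compounds alone.

Compound 2 `CCN(CC)c1cc(C)nc(N(CC)c2ccc(N(C)C)cc2Br)n1` was tested in an assay on isolated protein for binding affinity to corticotropin-releasing factor receptor 1 (Homo sapiens) (on this read-out lower numbers stand for stronger inhibition and higher numbers for weaker inhibition), and gave 27 nM. Among the two compounds measured so far, compound 2 has the higher number; its only companion, compound 1 `CCCCN(CC)c1cc(C)nc(N(CC)c2ccc(C(C)=O)cc2Br)n1`, gave 8 nM in this assay, a value that sits a step below compound 2 that goes beyond the usual scatter. Compound 1 and compound 2 differ at two places at once, so their gap cannot be laid to a single change.

Compound 3 `CCN(CC)c1cc(C)nc(N(CC)c2ccc(C(C)=O)cc2Br)n1` has not yet been measured. Compared with compound 2, the change in compound 3 is acetyl in place of dimethylamino on an aromatic carbon. Compound 3 thus carries the same acetyl group as compound 1 while keeping the diethylamino group of compound 2.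

Among the measured compounds shown here, with no single-change step between measured compounds available, the expectation for compound 3 rests on compound 1 and its value of 8 nM in this assay. Compound 3 is therefore expected to move toward stronger binding, a step of a 2.3-fold lower number from compound 2 to compound 3 (0.35 log units; beyond the scatter) in this assay. In this assay compound 3 is estimated at 12 nM, within a range from 4 nM to 40 nM.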

Compound 3, inhibition constant: 5 nM
Beside the measured number, compound 3's estimate is 2.4-fold (0.38 log units) above it; the range from low to high includes it.
By their numbers in this assay, from the lowest: compounds 3 and 1 (each within the scatter of the next); then compound 2.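

Among the compounds shown here, with compound 3, acetyl and dimethylamino can be compared on an otherwise unchanged structure for the first time: on this aromatic carbon, meta to a bromo group, the exchange gives a 5.4-fold lower number from compound 2 to compound 3 (0.73 log units; beyond the scatter) in this assay and shows that this position responds to the identity of the group, even though the leaving and entering groups each count 3 heavy atoms and 1 hydrogen-bond acceptor. Compound 3 also isolates the other difference between compound 1 and compound 2: hydrogen in place of ethyl on the saturated chain, two bonds along the chain from a nitrogen on an aromatic ring, gives a 1.6-fold lower number from compound 1 to compound 3 (0.20 log units; within the scatter) in this assay and so leaves the two compounds indistinguishable on this read-out. No measurement at hand bears on the reason for either step.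

On these data alone, only acetyl and dimethylamino are seen at this position, so how a nitrile, a methoxy group or a carboxylic acid would stand there remains open. For the compounds shown here, the saturated chain is likewise seen in only two lengths, which leaves open whether a hexyl chain or a cyclopropylmethyl group would keep the number of compound 3.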